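From Ethyl to Methyl on a Fluoro Compound

This account rests on a few compounds, and the source may have more. Where it says the series, first, only, none or still open, it means among the compounds named here.

In a functional assay on PC-3 cells (Homo sapiens) for cytotoxicity, read by MTT assay, with a stated time of 48 h (on this read-out higher numbers stand for weaker inhibition and lower numbers for stronger inhibition), compound 1 (`CCn1c(/C=C2/C(=O)Nc3ccc(F)cc32)nc2ccccc21`) gives > 50000 nM as its reading, which is a limit of the assay and not a number. In the same test compound 2 (`CCn1c(/C=C2/C(=O)Nc3ccccc32)nc2ccccc21`) gives 38000 nM as a measured value, and compound 3 (`CCn1c(/C=C2/C(=O)Nc3ccc(Br)cc32)nc2ccccc21`) gives 42700 nM as another.

Compound 4 (`Cn1c(/C=C2/C(=O)Nc3ccc(F)cc32)nc2ccccc21`) keeps the core of compound 1 and changes only the chain, ethyl to methyl: hydrogen in place of methyl on a saturated chain carbon bound to an aromatic nitrogen ( hydrogen in place of methyl on a saturated chain carbon bound to an aromatic nitrogen ).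

The measured steps swap only a group on an aromatic carbon. They read an at least 1.3-fold lower number from compound 1 to compound 2 (0.11 log units; that floor lies within the scatter) and an at least 1.1-fold lower number from compound 1 to compound 3 (0.06 log units; that floor lies within the scatter) and a 1.1-fold higher number from compound 2 to compound 3 (0.05 log units; within the scatter) in turn. None of them touches the chain, so they bear on this change only indirectly, by showing how closely these compounds read.

The estimated change is an at least 1.1-fold lower number from compound 1 to compound 4 (0.04 log units; that floor lies within the scatter) and no step beyond the scatter is expected in this assay on either side. Compound 4 is expected at about 45000 nM with an estimated range of 22000 nM to 90000 nM on this read-out.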

Compound 4, half-maximal inhibitory concentration: 34300 nM
Beside the measured number, compound 4's estimate is 1.3-fold (0.12 log units) above it; the range from low to high includes it.
By their numbers in this assay, from the lowest: compounds 4, 2 and 3 (each within the scatter of the next). At a limit, above all of these: compound 1.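

Methyl in place of ethyl gives the fluoro compound a measured number, and in this assay the change reads as an at least 1.4-fold lower number from compound 1 to compound 4 (0.16 log units; that floor lies within the scatter). Compound 1 gives > 50000 nM, which is a limit of the assay and not a number. The step is known only as a floor because compound 1 sits at that limit, so the true gap may be wider than the floor, though nothing shown says that it is: the limit of > 50000 nM in this assay, at which 1 of the 4 values shown sits.

The compounds shown leave open how a longer chain such as propyl, or a chain carrying an amine or a carboxylic acid, would read at this place. They also leave open whether the same change from ethyl to methyl would read alike with hydrogen, as in compound 2, or bromo, as in compound 3, on the aromatic carbon.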